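The source may report more compounds than this note shows. Statements on the series, on what has been measured and on what is new or still open speak of the compounds shown alone.

Compound 1 `COc1ccc(F)cc1C1CCN(c2ccn3c(CC(F)(F)F)nnc3c2Cl)CC1`: in an ADME assay on a cell-free system (plasma, Homo sapiens) for protein binding (a lower number here means a smaller unbound share, a higher number a larger unbound share of the compound), compound 1 gives < 0.01, which is a limit of the assay and not a number.
Compound 2 `COc1cccc(F)c1C1CCN(c2ccn3c(CC4CC4)nnc3c2Cl)CC1`: in this assay compound 2 gives < 0.01, again a limit.
Compound 3 `COc1c(F)cccc1C1CCN(c2ccn3c(CC4CC4)nnc3c2Cl)CC1`: in this assay compound 3 gives < 0.01, also a limit.

Compound 3 therefore stands where every measured compound stands, at the limit of < 0.01 in this assay, at which 3 of the 3 values shown sit. For the measured compounds named here, the only single-point step among them, a step that the two limits leave unreadable from compound 2 to compound 3, cannot be sized for that reason. Compound 4 `COc1c(F)ccc(F)c1C1CCN(c2ccn3c(CC4CC4)nnc3c2Cl)CC1` differs from compound 3 by fluoro in place of hydrogen on an aromatic carbon. Going by the values given here, no measured step offers a readable size for such a change, so the step that the limit leaves unreadable from compound 3 to compound 4 is expected to be none beyond the scatter. Compound 4 is thus estimated at 0.005, with a range from 0.002 to 0.012, most probably reported once more as a limit.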

Compound 4, unbound fraction: < 0.01
Compound 4: a limit, no number; the forecaster's own chance of this, stated with the estimate: 80%; the middle value lies beyond the limit too.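

Compound 4 also gives a limit and not a number, so the steps from compound 2 and from compound 3 to compound 4 cannot be read: the limit of < 0.01 in this assay, at which 4 of the 4 values shown sit. From the compounds shown here alone, how far a fluoro group on the aromatic ring shifts the unbound share in this assay stays open.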